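The source may hold more compounds than are shown below. What is called first, only, known or untested is meant among the compounds shown, and "the series" means these compounds.

In a functional assay on BT-549 cells (Homo sapiens) for inhibition, read by sulforhodamine B assay, with a stated time of 48 h, tested at 0.1 uM (on this read-out higher numbers stand for a weaker effect at the one concentration tested and lower numbers for a stronger effect), compound 3 `COc1cc(Cl)cc(-c2nn(-c3cccc(NC(=O)Nc4ccc(Cl)c(C(F)(F)F)c4)c3)cc2-c2ccncc2)c1` gives 99%, which is the highest of the three numbers measured, though none of the gaps to the other two reach beyond the scatter. Compound 1 `O=C(Nc1cccc(-n2cc(-c3ccncc3)c(-c3cc(O)cc(Cl)c3)n2)c1)Nc1ccc(Cl)c(C(F)(F)F)c1` gives 95% in this assay, and compound 2 `O=C(Nc1cccc(-n2cc(-c3ccncc3)c(-c3cc(O)cc(Cl)c3)n2)c1)Nc1ccc(Cl)c(Cl)c1` gives 93%. Compound 4 `COc1cc(Cl)cc(-c2nn(-c3cccc(NC(=O)Nc4ccc(Cl)c(Cl)c4)c3)cc2-c2ccncc2)c1` is not yet measured; it differs from compound 3 in one place, (chloro in place of trifluoromethyl on an aromatic carbon).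

Going by the values given here, one measured step bears directly on this change: a number 2 percentage points lower from compound 1 to compound 2 (within the scatter), the same exchange of chloro for trifluoromethyl on the same aromatic carbon, in the same place in the shared core. The other measured step, a number 4 percentage points higher from compound 1 to compound 3 (within the scatter), concerns the methyl in place of hydrogen on an oxygen that compound 3 and compound 4 share, so it does not alter the comparison. Among the compounds with values here, with compound 3 already near the top of the range in this assay, and the only relevant step within the scatter, no change beyond the scatter is expected from compound 3 to compound 4 in this assay. The account therefore expects for compound 4 a value of 97%, in a range from 88% to 103%, which amounts to an expected step of a number 2 percentage points lower from compound 3 to compound 4 (within the scatter).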

Compound 4, a percentage reported as activity, at one concentration (the size of the read-out at that concentration, not a potency): 98%
Compound 4: middle estimate off by 1 percentage points, on the low side; the range from low to high includes it.
By their numbers in this assay, from the lowest: compounds 2, 1, 4 and 3 (each within the scatter of the next).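

In this assay, chloro in place of trifluoromethyl on the aromatic carbon, ortho to a chloro group, can now be read on a second core, the one with methyl on the oxygen, where it gives a number 1 percentage points lower from compound 3 to compound 4 (within the scatter). Read on the two cores together, this exchange gives much the same small step each time, so the earlier result no longer rests on a single pair: the same change on two cores in this assay, a number 2 percentage points lower (within the scatter) from compound 1 to compound 2 and a number 1 percentage points lower (within the scatter) from compound 3 to compound 4, 1 percentage points apart, within the scatter of two such steps. The new compound also gives a second reading of methyl in place of hydrogen on the oxygen, a number 5 percentage points higher from compound 2 to compound 4 (within the scatter), and this change likewise stays within the scatter on both the trifluoromethyl and the chloro series: the same change on two cores in this assay, a number 4 percentage points higher (within the scatter) from compound 1 to compound 3 and a number 5 percentage points higher (within the scatter) from compound 2 to compound 4, 1 percentage points apart, within the scatter of two such steps.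

The compounds shown leave open whether a nitrile, an amine or a carboxylic acid on this aromatic carbon would move the number beyond the scatter, since only trifluoromethyl and chloro are compared there. They also leave open whether either change would separate the compounds at any other concentration, as every step here comes from the one concentration tested and none lies beyond the scatter.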